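The source may hold more compounds than are shown below. What is called first, only, known or untested is meant among the compounds shown, and "the series" means these compounds.

Measured so far in a functional assay on DU-145 cells (Homo sapiens) for cytotoxicity, read by MTT assay; on this read-out higher numbers stand for weaker inhibition and lower numbers for stronger inhibition:

- compound 1, `CC(O)(CS(=O)(=O)c1ccccc1)c1nc(-c2ccc(Cl)cc2)no1`: > 100000 nM, a limit only
- compound 2, `CC(O)(CS(=O)(=O)c1ccc(Br)cc1)c1nc(-c2ccc(Cl)cc2)no1`: > 100000 nM, again a limit
- compound 3, `CC(O)(CSc1ccccc1)c1nc(-c2ccc(Cl)cc2)no1`: 4500 nM

Compound 1 returns only the limit (the limit of > 100000 nM in this assay, at which 2 of the 3 values shown sit). Compound 2 sits at that same limit. Among the measured compounds shown here, compound 3 gives the single real number of the set. The step that the two limits leave unreadable from compound 1 to compound 2 is bromo in place of hydrogen on an aromatic carbon. The difference between the cores of compound 1 and compound 3 is not broken down here.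

Compound 4, `CC(O)(CSc1ccc(Br)cc1)c1nc(-c2ccc(Cl)cc2)no1`, still unmeasured, differs from compound 3 by bromo in place of hydrogen on an aromatic carbon, the same change as that between compound 1 and compound 2. Since a step that the two limits leave unreadable from compound 1 to compound 2 could not be read, the expected step of a 1.1-fold lower number from compound 3 to compound 4 (0.05 log units; within the scatter) rests on compound 3 alone and is taken as small, within ordinary scatter. Compound 4 is accordingly expected to land near 4000 nM, roughly between 1500 nM and 15000 nM.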

Compound 4, half-maximal inhibitory concentration: 6500 nM
Beside the measured number, compound 4's estimate is 1.6-fold (0.21 log units) below it; measured number inside the range.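

In this assay, bromo in place of hydrogen on an aromatic carbon gives a 1.4-fold higher number from compound 3 to compound 4 (0.16 log units; within the scatter), so on the core of compound 3 the change leaves no readable effect. The same change on the core of compound 1 cannot be read, as both of its ends are limits and not numbers: the limit of > 100000 nM in this assay, at which 2 of the 4 values shown sit.

Carrying the change from one core to the other is therefore neither supported nor contradicted, since only one core gives a readable step.

Open, on these data alone, is whether an amine or a carboxylic acid in place of bromo would move the number beyond the scatter on the core of compound 3. Also open, as far as these compounds go, is whether either group would bring the core of compound 1 to a readable number.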